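The source may hold more compounds than are shown below. What is called first, only, known or untested is meant among the compounds shown, and "the series" means these compounds.

Working notes on the acrylate series. Compound 1 `CCOC(=O)/C=C/c1ccncc1-c1ccc2ccccc2c1` is the ethyl ester of the set; in a functional assay on MCF7 cells (Homo sapiens) for inhibition, read by sulforhodamine B assay, with a stated time of 72 h (on this read-out lower numbers stand for stronger inhibition of growth and higher numbers for weaker inhibition of growth), compound 1 gives 8320 nM. Compound 2 `COC1CN(C(=O)/C=C/c2ccncc2-c2ccc3ccccc3c2)C1` is the corresponding amide. In this assay compound 2 reaches only > 10000 nM, which is a limit of the assay and not a number. Among the measured compounds shown here, the single measured step, an at least 1.2-fold higher number from compound 1 to compound 2 (0.07 log units; that floor lies within the scatter), is therefore known only as a floor, and its size is tied to the limit of > 10000 nM in this assay, at which 1 of the 2 values shown sits.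

Compound 3 `O=C(/C=C/c1ccncc1-c1ccc2ccccc2c1)N1CCOCC1` is the next amide to be measured. The change from compound 2 is morpholin-4-yl in place of 3-methoxyazetidin-1-yl on a carbonyl carbon. For the measured compounds named here, no measured step exchanges one amine for another on this carbonyl; the step from compound 1 to compound 2 bears on it only in that the amide end of the series has so far sat at the limit. On that basis the expected step that the limit leaves unreadable from compound 2 to compound 3 is none beyond the scatter, with a fair chance that this assay again reports only a limit. Compound 3 is estimated at 15000 nM, with a range of 5000 nM to 50000 nM.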

Compound 3, concentration for 50% growth inhibition: > 10000 nM
Compound 3 gave a limit, no number (the forecaster's own chance of this, stated with the estimate: 65%); the middle value lies beyond the limit too.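

In this assay compound 3 reaches only > 10000 nM, which is a limit of the assay and not a number. Against the ethyl ester, morpholin-4-yl on the carbonyl carbon gives an at least 1.2-fold higher number from compound 1 to compound 3 (0.07 log units; that floor lies within the scatter), so a second ring amide now yields only a floor, just as the 3-methoxyazetidin-1-yl amide did, and neither floor shows a change beyond the scatter. The step between the two amides cannot be read, so exchanging the four-membered ring for the six-membered one has no size, and the amide end of the series is defined so far by a single ceiling: the limit of > 10000 nM in this assay, at which 2 of the 3 values shown sit.

On these data alone, it remains open how far either amide lies past the limit and whether the true steps from the ethyl ester are large or small. Also open, as far as these compounds go, is whether any other group on this carbonyl carbon gives a readable number in this assay, for example an open-chain dimethylamino amide, a carboxylic acid or a longer-chain ester in place of ethoxy.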